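The source may report more compounds than this note shows. Statements on the series, on what has been measured and on what is new or still open speak of the compounds shown alone.

Compound 1 `Cc1nc(CC(C)(C)C)n2c(O)nncc12` was tested in a functional assay for inhibition, with Homo sapiens as the target; on this read-out lower numbers stand for stronger inhibition and higher numbers for weaker inhibition. In this assay compound 1 gives > 48000 nM, which is a limit of the assay and not a number. Compound 2 `Cc1nc(C(C)C)n2c(O)nncc12` shares the core and differs in one place. In this assay compound 2 gives > 48000 nM, again a limit and not a number. Within the data shown here, the step that the two limits leave unreadable from compound 1 to compound 2 therefore cannot be read, and compound 1 stands at a limit, with the one further value shown also a limit (the limit of > 48000 nM in this assay, at which 2 of the 2 values shown sit). Compound 3 `Cc1nc(Cc2ccccc2)n2c(O)nncc12` differs from compound 1 by phenyl in place of tert-butyl on a saturated chain carbon bound to an aromatic carbon. Among the measured compounds shown here, no measured step matches this change, and the only step recorded, a step that the two limits leave unreadable from compound 1 to compound 2, is of unreadable size, so no direction beyond the scatter can be expected in this assay. Compound 3 is expected to give 60000 nM in this assay, between 15000 nM and 240000 nM. This means an expected step that the limit leaves unreadable from compound 1 to compound 3.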

Compound 3, half-maximal inhibitory concentration: > 48000 nM
Compound 3 ended at the assay's limit; the forecaster's own chance of this, stated with the estimate: 75%; the middle value lies beyond the limit too.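

Compound 3, like compound 1, stands at a limit and not at a number, so the step from compound 1 to compound 3 cannot be read: the limit of > 48000 nM in this assay, at which 3 of the 3 values shown sit.

The compounds shown leave open how far apart these three lie in this assay, and whether any change on the shared core gives a readable value.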